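Shortening a Side Chain on a Shared Core

The compounds below may be only part of what the source reports. "The series", "measured", "known", "first", "only" and "open" are said of these compounds alone.

Three compounds of one series share a core that carries an aromatic ring with a variable group at one end. Compound 1 `CCn1nnc(-c2ccc(OCCC(C)CCN3CCN(c4ccncc4)C3=O)cc2)n1` carries a 2-ethyl-2H-tetrazol-5-yl group there, compound 2 `CCCc1nc(-c2ccc(OCCC(C)CCN3CCN(c4ccncc4)C3=O)cc2)no1` a 5-propyl-1,2,4-oxadiazol-3-yl group, and compound 3 `CCCC(CCOc1ccc(-c2ccc(Cl)cc2)cc1)CCN1CCN(c2ccncc2)C1=O` a different aromatic group on a longer chain. All three were tested in an ADME assay on cells (Homo sapiens) for cytotoxicity; a higher number here means that more compound is tolerated, a lower number that less compound is tolerated. Compound 1 reached only the limit of the measurement, > 12500 nM. Compound 2 likewise gives only a limit, > 12500 nM. Compound 3 gives a limit as well, > 25000 nM. With both of its ends at a limit, the step that the two limits leave unreadable from compound 1 to compound 2 cannot be read. Compound 2 thus stands at a limit rather than at a number, and the two other values shown are limits too.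

Compound 4 `CCc1nc(-c2ccc(OCCC(C)CCN3CCN(c4ccncc4)C3=O)cc2)no1` differs from compound 2 by a single change: hydrogen in place of methyl on a saturated chain carbon, two bonds along the chain from an aromatic carbon. No readable measured step bears on this change. What is known is the limit of > 12500 nM in this assay, at which 2 of the 3 values shown sit, and (the limit of > 25000 nM in this assay, at which 1 of the 3 values shown sits). No step beyond the scatter is expected, and the step from compound 2 to compound 4 is estimated as a step that the limit leaves unreadable from compound 2 to compound 4. Compound 4 is expected to give 20000 nM, with a range from 10000 nM to 50000 nM, most likely again reported as a limit.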

Compound 4, half-maximal cytotoxic concentration: > 25000 nM
Compound 4: no number, only a limit (the forecaster's own chance of this, stated with the estimate: 85%); at least 1.2-fold (0.09 log units) between middle value and limit.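

Compound 4 again gives only a limit, not a number: the limit of > 25000 nM in this assay, at which 2 of the 4 values shown sit. Among the compounds shown here, with limits at both ends, neither the step from compound 2 to compound 4 nor the one from compound 1 to compound 4 can be read. The compounds shown leave open whether changing 5-propyl-1,2,4-oxadiazol-3-yl to 5-ethyl-1,2,4-oxadiazol-3-yl alters the result in this assay at all.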